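From 2-methylphenyl to 2-fluorophenyl: working notes

The source may hold more compounds than are shown below. What is called first, only, known or untested is meant among the compounds shown, and "the series" means these compounds.

Measured in a functional assay on KBVIN cells (Homo sapiens) for antiproliferative activity, read by sulforhodamine B assay, with a stated time of 3 days; on this read-out lower numbers stand for an effect already at smaller amounts and higher numbers for an effect only at larger amounts of compound:
- compound 1 `CCC1=C(O)c2c(oc(-c3ccc(C(C)C)cc3)cc2=O)C(CC)(CC)C1=O`: 1.08 uM
- compound 2 `CCC1=C(O)c2c(oc(-c3ccccc3C)cc2=O)C(CC)(CC)C1=O`: 2.41 uM

Compound 2 has the higher of the two numbers in this assay, at 2.41 uM. Among the measured compounds shown here, its only neighbour is compound 1, at 1.08 uM.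

Next in line is compound 3 `CCC1=C(O)c2c(oc(-c3ccccc3F)cc2=O)C(CC)(CC)C1=O`, which has fluoro in place of methyl on an aromatic carbon, ortho to a large group: fluoro in place of methyl on an aromatic carbon. The same difference reads 2-methylphenyl to 2-fluorophenyl.

For the measured compounds named here, only one measured step bears on this change: a 2.2-fold higher number from compound 1 to compound 2 (0.35 log units; beyond the scatter). It is modest and involves the same aromatic substituent, but it replaces 4-isopropylphenyl with 2-methylphenyl, a different change from the one at hand. Going by the values given here, no measured compound yet shows the effect of fluoro, so the direction remains open. The exchange of methyl for fluoro is small, so no step beyond the scatter is expected.

The expected change is a 1.0-fold higher number from compound 2 to compound 3 (0.02 log units; within the scatter). For compound 3 the estimated value is 2.5 uM, with an expected range from 1 uM to 6 uM.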

Compound 3, concentration for half-maximal effect: 3.93 uM
Compound 3: middle estimate off by 1.6-fold (0.20 log units), on the low side, within the range that was stated.
By their numbers in this assay, from the lowest: compound 1; then compounds 2 and 3 (each within the scatter of the next).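

Fluoro in place of methyl on an aromatic carbon, ortho to a large group, gives a 1.6-fold higher number from compound 2 to compound 3 (0.21 log units; within the scatter) in this assay, so at this position the series does not separate the 2-fluorophenyl compound from the 2-methylphenyl compound. The earlier pair showed only that 2-methylphenyl differs from 4-isopropylphenyl; with a 3.6-fold higher number from compound 1 to compound 3 (0.56 log units; beyond the scatter) added, 2-fluorophenyl in place of 4-isopropylphenyl also reads beyond the scatter, and compound 1 keeps the lowest number of the three, with its steps to both others printed as beyond the scatter. No measurement of any property of these groups stands beside the numbers, and so the values can be described here but not explained.

Compound 1 differs from compound 2 and compound 3 both in the group itself and in where that group sits on the ring, and the three compounds shown cannot separate those two contributions. Also open, going by these compounds, is how a methoxy group or an amine on the same aromatic carbon would read, and whether the small difference between fluoro and methyl would persist with either of them in the comparison.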